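Adding a chloro-nitro ring to a diaryl ether urea

The source may hold more compounds than are shown below. What is called first, only, known or untested is meant among the compounds shown, and "the series" means these compounds.

The three compounds share one core: a urea that links two aromatic rings, one of which carries an ether bridge to a second ring bearing a thiazole. Compound 1 `O=C(Nc1ccc(Cl)cc1)Nc1ccc(Oc2ccc(-c3nccs3)cc2)cc1` has a 4-chlorophenyl group on the far urea nitrogen. In a functional assay on MDA-MB-231 cells (Homo sapiens) for inhibition, read by MTT assay and WST assay, with a stated time of 72 h, tested at 10 uM (on this read-out higher numbers stand for more inhibition of growth at the one concentration tested and lower numbers for less inhibition of growth), compound 1 gives 32.5%. Compound 2 `O=C(Nc1ccccc1)Nc1ccc(Oc2ccc(-c3nccs3)cc2)cc1` carries a plain phenyl group at that position; in this assay compound 2 gives "not determined" (no result reported), so no number is available for it and its position can be judged only from its neighbour compound 1. Compound 3 `O=C(Nc1ccc(Oc2ccc(-c3nccs3)cc2)cc1)Nc1ccc(Cl)c([N+](=O)[O-])c1` is the next step: 4-chloro-3-nitrophenyl in place of phenyl on an amide-type nitrogen. The change introduces both the chlorine seen in compound 1 and an additional nitro group on the same ring. Because compound 1 reaches 32.5% with its chlorine alone, compound 3 is expected to land in the same general region, with a modest upward shift that may or may not exceed the usual scatter. For compound 3 the expected growth inhibition in this assay is 40%, with a likely range from 20% to 60%.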

Compound 3, percent growth inhibition at one concentration: 72.8%
Estimate against measurement, compound 3: 32.8 percentage points below; the whole stated range lies below it.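

The ring on the amide-type nitrogen is a sensitive place in this series: in this assay, nitro in place of hydrogen on the aromatic carbon gives a number 40.3 percentage points higher from compound 1 to compound 3 (beyond the scatter) and shows that one added group on a ring already carrying chlorine can change growth inhibition well beyond the variation between repeat measurements. From the compounds shown here alone, compound 2 has no reported number, so the larger change from phenyl to 4-chloro-3-nitrophenyl cannot be read, and the contribution of the chlorine on its own remains unknown. No measurement here gives a reason for the size of the step seen with the nitro group.

Going by these compounds, it remains open whether the nitro group itself matters or whether a nitrile, an amine or a carboxylic acid at the same place on the ring would give a similar result. On these data alone, it is also open whether a nitro group on a ring without the chlorine would reach a similar level of growth inhibition, and the single tested concentration gives no measure of potency across a range of concentrations.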